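An Aryl Exchange Among Three Readings at the Limit

The compounds below may be only part of what the source reports. "The series", "measured", "known", "first", "only" and "open" are said of these compounds alone.

Compound 1 `CCOC(=O)C1=Cc2ccccc2OC1(OCc1cc(-c2ccc(F)cc2F)no1)C(F)(F)F` was examined in a functional assay on MCF7 cells (Homo sapiens) for inhibition, read by MTT assay, with a stated time of 24 h; on this read-out lower numbers stand for stronger inhibition and higher numbers for weaker inhibition. In this assay compound 1 gives > 150000 nM, which is a limit of the assay and not a number. Compound 2 `CCOC(=O)C1=Cc2ccccc2OC1(OCc1cn(-c2ccccc2)nn1)C(F)(F)F` gives > 150000 nM, also a limit. Compound 3 `O=C(O)C1=Cc2ccccc2OC1(OCc1cc(-c2ccc(F)cc2F)no1)C(F)(F)F` gives > 150000 nM, again a limit. The step that the two limits leave unreadable from compound 1 to compound 3 is therefore unreadable, as all three readings sit at the limit of > 150000 nM in this assay, at which 3 of the 3 values shown sit. Compound 4 `CCOC(=O)C1=Cc2ccccc2OC1(OCc1cc(-c2cccc(C(F)(F)F)c2)no1)C(F)(F)F` differs from compound 1 by 3-(trifluoromethyl)phenyl in place of 2,4-difluorophenyl on an aromatic carbon. Among the compounds with values here, no measured step involves this kind of aryl exchange, and none of the measured steps has a readable size, so no direction can be drawn from them. Compound 4 is accordingly expected to stay at the limit, with an estimated value of 200000 nM within 50000 nM to 1000000 nM. The expected step is a step that the limit leaves unreadable from compound 1 to compound 4, which is not expected to exceed the scatter.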

Compound 4, half-maximal inhibitory concentration: 22100 nM
Estimate against measurement, compound 4: 9.0-fold (0.96 log units) above; measured number below the stated range.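

Within the data shown here, with 3-(trifluoromethyl)phenyl in place of 2,4-difluorophenyl, this assay gives an at least 6.7-fold lower number from compound 1 to compound 4 (0.83 log units; beyond the scatter), the only step of readable size in the set. This shows that the aryl group on this aromatic carbon, next to the ring nitrogen, can move the reading off the limit, which the earlier compounds could not show, as their steps cannot be read: the limit of > 150000 nM in this assay, at which 3 of the 4 values shown sit.

The compounds shown leave open whether a nitrile or an amine on the phenyl ring would give a similar step. They also leave open how the carboxylic acid in place of the ethyl ester would read alongside 3-(trifluoromethyl)phenyl.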